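The compounds below may be only part of what the source reports. "The series", "measured", "known", "first", "only" and "open" are said of these compounds alone.

In an ADME assay on microsomes from liver (Rattus norvegicus) for metabolic stability, using NADPH, with a stated time of 10 min; a higher number here means that more of the compound is left, a lower number that less of the compound is left:
- compound 1 `NCCCCN(C[C@H]1Cc2nccnc2CN1)[C@H]1CCCc2cccnc21`: 50%
- compound 2 `NC/C=C\CN(C[C@H]1Cc2ncccc2CN1)[C@H]1CCCc2cccnc21`: 11%

Compound 2 stands lowest of the two, and the gap to compound 1 lies beyond the usual scatter. Compound 3 `CCN(CC)CCCCN(C[C@H]1Cc2ncccc2CN1)[C@H]1CCCc2cccnc21` keeps the core of compound 2 but carries 3-(diethylamino)propyl in place of 3-aminoprop-1-en-1-yl on a saturated chain carbon bound to an amine nitrogen. For the measured compounds named here, no measured pair shows this change, so the expectation starts from compound 2 at 11%. No shift beyond the scatter is expected in this assay, with an estimated a number 2 percentage points higher from compound 2 to compound 3 (within the scatter). For compound 3 the expected value is 13%, within an estimated range of 3% to 32%.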

Compound 3, percent of the compound remaining: 6%
Estimate against measurement, compound 3: 7 percentage points above, and the stated range covers the measured number.
By their numbers in this assay, from the lowest: compounds 3 and 2 (each within the scatter of the next); then compound 1.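

In this assay the swap of 3-aminoprop-1-en-1-yl for 3-(diethylamino)propyl on a saturated chain carbon bound to an amine nitrogen gives a number 5 percentage points lower from compound 2 to compound 3 (within the scatter) and so leaves the read-out unresolved between the two compounds. For the compounds shown here, at this position, then, enlarging the group, losing its double bond and losing its hydrogen-bond donor together produce no step that can be told from scatter. Nothing measured here explains this result. Still open, as far as these compounds go, is whether a carboxylic acid or an amide at the end of this chain would read differently on the core of compound 2.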